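Isobutyl for 1,1-dimethylpropyl on a carbonyl carbon

The source may report more compounds than this note shows. Statements on the series, on what has been measured and on what is new or still open speak of the compounds shown alone.

In a functional assay on NCI-H460 cells (Homo sapiens) for cytotoxicity, read by MTT assay, with a stated time of 48 h (on this read-out lower numbers stand for stronger inhibition and higher numbers for weaker inhibition), compound 3 (`C=C1C(=O)O[C@H]2CC3=C[C@H](C/C(C)=C/[C@@H](OC(=O)C(C)(C)CC)[C@H]12)OC3=O`) gives 6100 nM. Within the data shown here, compound 1 (`C=C1C(=O)O[C@H]2CC3=C[C@H](C/C(C)=C/[C@@H](OC(=O)/C=C/c4ccc(N(C)C)cc4)[C@H]12)OC3=O`) gives 1300 nM, the only other number. The gap between these two is a 4.7-fold higher number from compound 1 to compound 3 (0.67 log units; beyond the scatter), which leaves compound 3 with the higher number. Compound 2 (`C=C1C(=O)O[C@H]2CC3=C[C@H](C/C(C)=C/[C@@H](OC(=O)CCl)[C@H]12)OC3=O`) reads > 10000 nM, which is a limit of the assay and not a number.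

Compound 4 (`C=C1C(=O)O[C@H]2CC3=C[C@H](C/C(C)=C/[C@@H](OC(=O)CC(C)C)[C@H]12)OC3=O`) carries isobutyl in place of 1,1-dimethylpropyl on a carbonyl carbon. Among the measured compounds shown here, no measured pair makes this exact exchange. The two larger steps, a 4.7-fold higher number from compound 1 to compound 3 (0.67 log units; beyond the scatter) and an at least 7.6-fold higher number from compound 1 to compound 2 (0.88 log units; beyond the scatter), both remove the 2-(4-(dimethylamino)phenyl)ethenyl group. That group is absent on both sides of the new exchange, so these steps bear on it only loosely. For the measured compounds named here, the closest guide is the one measured step that leaves this group out of play, an at least 1.6-fold lower number from compound 2 to compound 3 (0.21 log units; that floor lies within the scatter), and its floor lies within the scatter. On that basis, no step beyond the scatter is expected in this assay, and the estimated change is a 1.1-fold higher number from compound 3 to compound 4 (0.06 log units; within the scatter), with no firm direction. Compound 4 is expected at 7000 nM, with an estimated range of 3500 nM to 14000 nM.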

Compound 4, half-maximal inhibitory concentration: 3800 nM
Beside the measured number, compound 4's estimate is 1.8-fold (0.27 log units) above it; low and high end bracket the measured number.
By their numbers in this assay, from the lowest: compound 1; then compounds 4 and 3 (each within the scatter of the next). At a limit, above all of these: compound 2.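

In this assay, isobutyl in place of 1,1-dimethylpropyl on a carbonyl carbon gives the first direct read between two saturated carbon groups at this position, and the result is a 1.6-fold lower number from compound 3 to compound 4 (0.21 log units; within the scatter), so this exchange does not separate the two compounds. Two further steps place the new compound in the series: a 2.9-fold higher number from compound 1 to compound 4 (0.47 log units; beyond the scatter) shows that isobutyl, like 1,1-dimethylpropyl, does not match the 2-(4-(dimethylamino)phenyl)ethenyl group, while an at least 2.6-fold lower number from compound 2 to compound 4 (0.42 log units; beyond the scatter) gives a floor that clears the scatter, which the corresponding floor for 1,1-dimethylpropyl did not do. Compound 2 reads > 10000 nM, which is a limit of the assay and not a number: the limit of > 10000 nM in this assay, at which 1 of the 4 values shown sits.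

From the compounds shown here alone, it remains open whether the advantage of the 2-(4-(dimethylamino)phenyl)ethenyl group rests on the dimethylamino group, the phenyl ring or the ethenyl link, and a plain 2-phenylethenyl group would address that question. Going by these compounds, it is also open whether a longer chain, or a chain ending in an amine or a carboxylic acid, would shift the number at this position in either direction.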